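Swapping a Ring for a Branched Chain on the Amine

This account rests on a few compounds, and the source may have more. Where it says the series, first, only, none or still open, it means among the compounds named here.

Compound 1 `CC(C)c1nc(C(=O)NC[C@@H]2[C@H]3CN(CC4CCC4)C[C@@H]23)c2ccccn12`: 50%
Compound 2 `CC(C)c1nc(C(=O)NC[C@@H]2[C@H]3CN(C4CCOCC4)C[C@@H]23)c2ccccn12`: 43%

In a functional assay on CHO cells for agonist activity at 5-hydroxytryptamine receptor 4 (Homo sapiens), read by a luciferase reporter and cAMP accumulation, with a stated time of 4 h (a higher number here means a larger maximal response, a lower number a smaller maximal response), compound 2 gives 43%. Among the compounds with values here, only one other compound has been measured, and the step of a number 7 percentage points lower from compound 1 to compound 2 (within the scatter) is within the scatter, so compound 2 stands alongside compound 1 rather than apart from it. Compound 3 `CC(C)c1nc(C(=O)NC[C@@H]2[C@H]3CN(CC(C)(C)CO)C[C@@H]23)c2ccccn12` differs from compound 2 by 2-(hydroxymethyl)-2-methylpropyl in place of oxan-4-yl on an amine nitrogen in a ring. Within the data shown here, the single measured step, a number 7 percentage points lower from compound 1 to compound 2 (within the scatter), also changed the group on that same amine nitrogen and stayed within the scatter; no measured step bears on this chain directly. A step of a number 2 percentage points higher from compound 2 to compound 3 (within the scatter) that stays within the scatter is therefore expected. Compound 3 is estimated at 45%, with a range from 30% to 60%.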

Compound 3, largest response reached (Emax), in percent of the reference or control that the assay uses: 40%
Compound 3: middle estimate off by 5 percentage points, on the high side; low and high end bracket the measured number.
By their numbers in this assay, from the lowest: compounds 3, 2 and 1 (each within the scatter of the next).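

In this assay, replacing the oxan-4-yl ring on the amine nitrogen with the open 2-(hydroxymethyl)-2-methylpropyl chain, which carries a hydrogen-bond donor, gives a number 3 percentage points lower from compound 2 to compound 3 (within the scatter), and the comparison with the cyclobutylmethyl group gives a number 10 percentage points lower from compound 1 to compound 3 (within the scatter). Across these three compounds, then, this nitrogen accepts a ring or an open chain, with or without that donor, without a change beyond the scatter. Nothing at hand explains this result.

Still open, from the compounds shown here alone, is whether a carboxylic acid or an amine at the end of a longer chain on this nitrogen would move the maximal response beyond the scatter.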